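The source may hold more compounds than are shown below. What is called first, only, known or untested is meant among the compounds shown, and "the series" means these compounds.

Measured so far in an assay on nucleic acid for inhibition of Nucleic Acid, read by fluorescence, tested at 100 uM; on this read-out lower numbers stand for less inhibition and higher numbers for more inhibition at the one concentration tested (going by the name of the read-out):
- compound 1 `CN(Cc1cn(C2CCCCC2O)nn1)CC1CCCCC1` gives 47%
- compound 2 `CC(C)CCN(C)Cc1cn(CC(O)COC(=O)C2CCCCC2)nn1` gives 0%
- compound 3 `OC1CCCCC1n1cc(CN2CCN(c3ccccc3)CC2)nn1` gives 47%

Compound 2 stands lowest of the three numbers in this assay; compound 1 and compound 3 both sit a long way higher, beyond the usual scatter, while those two lie within the scatter of each other. No pair of these compounds differs in just one place, so no single step has been worked out.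

Compound 4 `CC(C)CCN(C)Cc1cn(CC(O)COC(=O)NCc2ccccc2)nn1` is the next candidate. Relative to compound 2 it carries benzylamino in place of cyclohexyl on a carbonyl carbon. Given that compound 2 gives 0%, the step is expected to be small and within the scatter, estimated as a number 5 percentage points higher from compound 2 to compound 4 (within the scatter). Compound 4 is therefore estimated at 5%, with a range from 0% to 20%.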

Compound 4, a percentage reported as inhibition, at one concentration (the size of the read-out at that concentration, not a potency): 26%
Compound 4: the middle estimate sits 21 percentage points below what was measured; measured number outside the range, above it.
By their numbers in this assay, from the lowest: compound 2; then compound 4; then compounds 1 and 3 (each within the scatter of the next).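

In this assay benzylamino in place of cyclohexyl on a carbonyl carbon gives a number 26 percentage points higher from compound 2 to compound 4 (beyond the scatter) and so shows that the group at this place can shift the read-out. The swap changes the ring to an aromatic one and also brings in a nitrogen with a hydrogen-bond donor, and this one step does not separate those changes. No measured evidence bears on the reason for the step. Still open, from the compounds shown here alone, is how cyclohexylamino or phenylamino would read here, which would help separate the nitrogen from the aromatic ring.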